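A few compounds are considered here, and "the series" means these few. Any claim that something is new, unique, unknown or untested is made for them only; others in the source may bear on it.

Compound 2, with the structure `NS(=O)(=O)c1ccc(-c2nc3cc([N+](=O)[O-])ccc3[nH]2)cc1`, is one of three compounds examined in a functional assay for antagonist activity at Neuropeptides B/W receptor type 1 (Homo sapiens), read by cAMP accumulation (on this read-out higher numbers stand for weaker inhibition and lower numbers for stronger inhibition), and its result there is a limit of the assay rather than a number: in this assay compound 2 gives > 31600 nM. Compound 1, `FC(F)(F)c1ccc2[nH]c(-c3ccccc3)nc2c1`, is the only one of the three with a measured number, since in this assay compound 1 gives 1200 nM. Compound 3, `CC(=O)c1ccccc1-c1nc2cc([N+](=O)[O-])ccc2[nH]1`, also sits at a limit in this assay, where compound 3 gives > 31600 nM. Thus the data show (the limit of > 31600 nM in this assay, at which 2 of the 3 values shown sit), and compound 2 stands at the weak end of what has been shown, without a number of its own.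

The next compound, compound 4, has the structure `CC(C)(C)c1ccc(-c2nc3cc([N+](=O)[O-])ccc3[nH]2)cc1`. It differs from compound 2 by tert-butyl in place of sulfamoyl on an aromatic carbon, para to a large group.

No pair of measured compounds differs in one place, so the size of this step cannot be read from the figures shown. Because compound 2 sits at > 31600 nM, a change is expected in the direction of stronger inhibition, though its size is uncertain. For compound 4 in this assay the estimate is 8000 nM, in a range from 1500 nM to 31600 nM, which would mean an expected step of an at least 3.9-fold lower number from compound 2 to compound 4 (0.59 log units; beyond the scatter).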

Compound 4, half-maximal inhibitory concentration: 3180 nM
Estimate against measurement, compound 4: 2.5-fold (0.40 log units) above, and the stated range covers the measured number.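

Replacing sulfamoyl with tert-butyl on an aromatic carbon, para to a large group, gives an at least 9.9-fold lower number from compound 2 to compound 4 (0.99 log units; beyond the scatter) in this assay. This pair shows that the group at this position alone can change the read-out on the core shared by compound 2 and compound 4, and that a group with no hydrogen-bond donors or acceptors is compatible with measurable inhibition here. Compound 4 gives 3180 nM, a measured number. Compound 2 gives > 31600 nM, which is a limit and not a number, so the step sets only a bound on the size of the change: the limit of > 31600 nM in this assay, at which 2 of the 4 values shown sit.

From the compounds shown here alone, a single pair cannot tell whether the difference comes from the tert-butyl that enters or the sulfamoyl that leaves, and it remains open how a methyl group, a chlorine atom, a methoxy group or an amine would read at this position. The compounds shown also leave open whether tert-butyl would bring a step of similar size on a core carrying a different group in place of the one shared by compound 2 and compound 4.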